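Amide Replaced by Acid on a Shared Pyridine Core

The source may hold more compounds than are shown below. What is called first, only, known or untested is meant among the compounds shown, and "the series" means these compounds.

Measured compounds:
compound 1, `COC1CN(C(=O)/C=C/c2ccncc2-c2ccc3ccccc3c2)C1`: 42.8 nM
compound 2, `O=C(/C=C/c1ccncc1-c1ccc2cc[nH]c2c1)N1CCOCC1`: 43.9 nM
compound 3, `COC1CN(C(=O)/C=C/c2ccncc2-c2ccc(F)cc2)C1`: "not determined" (no result reported)

In an assay on a protein complex for inhibition of CDK8/Cyclin C (Homo sapiens), with a stated time of 1 h (a higher number here means a weaker inhibitor, a lower number a stronger inhibitor), compound 1 gives 42.8 nM and compound 2 gives 43.9 nM; the two numbers lie within the scatter of one another, so neither can be set above the other. In this assay compound 3 gives "not determined" (no result reported), so no number stands for it.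

Compound 4, `O=C(O)/C=C/c1ccncc1-c1ccc2ccccc2c1`, differs from compound 1 by one change: hydroxy in place of 3-methoxyazetidin-1-yl on a carbonyl carbon. Going by the values given here, no measured pair shows this step, so its size is open. The author expects a sizeable shift toward a higher number, beyond the scatter, rather than none. Compound 4 is therefore estimated at 800 nM, with a range from 150 nM to 5000 nM. This estimate corresponds to an expected step of a 19-fold higher number from compound 1 to compound 4 (1.27 log units; beyond the scatter).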

Compound 4, half-maximal inhibitory concentration: 5 nM
For compound 4 the middle estimate is 160-fold (2.20 log units) above the measured one; the whole stated range lies above it.
By their numbers in this assay, from the lowest: compound 4; then compounds 1 and 2 (each within the scatter of the next).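

Going from (3-methoxyazetidin-1-yl)carbonyl to carboxy on this carbonyl carbon gives an 8.6-fold lower number from compound 1 to compound 4 (0.93 log units; beyond the scatter) in this assay. Going by these compounds alone, this is the first readable step at this position, and it shows that the ring on the carbonyl carbon is not needed for a low number here; the smaller hydroxy gives a lower one. Nothing measured here accounts for the step. The compounds shown leave open how a methyl ester or a primary amide on the same carbonyl carbon would compare. They also leave open whether the step would carry over to other groups on the shared core.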